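The source may hold more compounds than are shown below. What is called first, only, known or untested is meant among the compounds shown, and "the series" means these compounds.

Measured in an ADME assay on MCF7-DOX cells (Homo sapiens) for cytotoxicity, read by MTT assay, with a stated time of 48 h; a lower number here means a stronger inhibitor, a higher number a weaker inhibitor:
- compound 1 `COc1cc(OC)c(C(=O)/C=C/c2cccc(F)c2)c(O)c1CC=C(C)C`: 45400 nM
- compound 2 `COc1cc(OC)c(C(=O)/C=C/c2ccc(C(F)(F)F)cc2)c(O)c1CC=C(C)C`: 73700 nM
- compound 3 `COc1cc(OC)c(C(=O)/C=C/c2cccc(C(F)(F)F)c2)c(O)c1CC=C(C)C`: 66600 nM

Compound 3 stands within the scatter of both other compounds in this assay: the steps are a 1.5-fold higher number from compound 1 to compound 3 (0.17 log units; within the scatter) and a 1.1-fold lower number from compound 2 to compound 3 (0.04 log units; within the scatter). Compound 4 `COc1cc(OC)c(C(=O)/C=C/c2ccc(Cl)cc2)c(O)c1CC=C(C)C` carries a new group on the shared core: 4-chlorophenyl in place of 3-(trifluoromethyl)phenyl on a double-bonded chain carbon bound to a double-bonded chain carbon. In words, this is 4-chlorophenyl in place of 3-(trifluoromethyl)phenyl on a double-bonded chain carbon bound to a double-bonded chain carbon.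

Going by the values given here, no measured compound bears a chlorine, so no step shows this exact change. The nearest evidence is the set of changes to the same aryl group, which also includes a 1.6-fold higher number from compound 1 to compound 2 (0.21 log units; within the scatter). All three steps stayed within the scatter, so none beyond the scatter is expected here, and no direction can be called. The expected step is a 1.2-fold lower number from compound 3 to compound 4 (0.08 log units; within the scatter). For compound 4 the estimated value is 55000 nM, with an expected range from 30000 nM to 100000 nM.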

Compound 4, half-maximal inhibitory concentration: 43400 nM
Beside the measured number, compound 4's estimate is 1.3-fold (0.10 log units) above it, within the range that was stated.
By their numbers in this assay, from the lowest: compounds 4, 1, 3 and 2 (each within the scatter of the next).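

In this assay, going by these compounds alone, the 4-chlorophenyl group brings a chlorine to the double-bonded chain carbon for the first time, and the steps of a 1.5-fold lower number from compound 3 to compound 4 (0.19 log units; within the scatter) and a 1.7-fold lower number from compound 2 to compound 4 (0.23 log units; within the scatter) and also a 1.0-fold lower number from compound 1 to compound 4 (0.02 log units; within the scatter) all lie within the scatter. Chloro in place of trifluoromethyl on an aromatic carbon therefore joins the earlier fluoro and trifluoromethyl swaps, so all four aryl groups shown at this place remain indistinguishable in this assay and none can be ranked. Nothing shown offers a measured explanation for this result.

The compounds shown carry only halogen or trifluoromethyl groups on this aryl ring, so they leave open whether an amine or a carboxylic acid there would give a step beyond the scatter. They also leave open whether the same flat picture would hold in any other assay.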